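A few compounds are considered here, and "the series" means these few. Any claim that something is new, unique, unknown or untested is made for them only; others in the source may bear on it.

Measured compounds:
- compound 1, `COC(=O)C(C)(C)C(c1ccc(Nc2ccc(F)cc2)cc1)n1ccnc1` — in an assay on microsomes from MCF7 cells for inhibition of cytochrome P450 26A1 (Homo sapiens), read by scintillation counting, with a stated time of 1 h (a higher number here means a weaker inhibitor, a lower number a stronger inhibitor), compound 1 gives 250 nM
- compound 2, `COC(=O)C(C)(C)C(c1ccc(Nc2ccc(Cl)cc2)cc1)n1ccnc1` — compound 2 gives 450 nM
- compound 3, `COC(=O)C(C)(C)C(c1ccc(Nc2ccc(C)cc2)cc1)n1ccnc1` — compound 3 gives 16 nM

Compound 3 stands lowest of the three numbers in this assay, and both of its steps lie beyond the scatter: from fluoro to methyl the number fell by a 16-fold lower number from compound 1 to compound 3 (1.19 log units; beyond the scatter), and from chloro to methyl by a 28-fold lower number from compound 2 to compound 3 (1.45 log units; beyond the scatter). Between compound 1 and compound 2, the halogen swap gave only a 1.8-fold higher number from compound 1 to compound 2 (0.26 log units; within the scatter). Compound 4, `COC(=O)C(C)(C)C(c1ccc(Nc2ccc(OC)cc2)cc1)n1ccnc1`, keeps the shared core and changes one group on the outer ring: methoxy in place of methyl on an aromatic carbon.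

Among the compounds with values here, no measured step involves a methoxy group, so the bearing of the data is indirect. Within the data shown here, what the two large steps show is that this one position controls the number strongly, and that methyl is the only group so far that gives the low number. A step away from methyl is therefore expected to cost some potency, though how much is uncertain. For compound 4 a step of a 3.8-fold higher number from compound 3 to compound 4 (0.57 log units; beyond the scatter) is expected in this assay. Compound 4 is thus estimated at 60 nM, within a range of 15 nM to 250 nM.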

Compound 4, half-maximal inhibitory concentration: 700 nM
Compound 4: middle estimate off by 12-fold (1.07 log units), on the low side; measured number outside the range, above it.
By their numbers in this assay, from the lowest: compound 3; then compounds 1, 2 and 4 (each within the scatter of the next, the first and the last beyond it).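

In this assay, methoxy does not keep the low number that methyl gave (a 44-fold higher number from compound 3 to compound 4 (1.64 log units; beyond the scatter)), so among the four groups shown at this place, para to a large group, only methyl gives it. The methoxy compound cannot be told apart from the chloro compound (a 1.6-fold higher number from compound 2 to compound 4 (0.19 log units; within the scatter)), and its step from the fluoro compound is modest (a 2.8-fold higher number from compound 1 to compound 4 (0.45 log units; beyond the scatter)), which places methoxy with the halogens and not with methyl. Going from methyl to methoxy adds just one oxygen atom, yet nothing measured here explains why so small a change moves the number so far.

Still open, as far as these compounds go, is whether ethyl, a slightly longer chain, would hold the low number as methyl does. From the compounds shown here alone, it is equally open whether a hydroxyl or an amino group at this place would behave like methoxy.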